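From butyl to 4-methylphenyl on an aromatic nitrogen

The source may report more compounds than this note shows. Statements on the series, on what has been measured and on what is new or still open speak of the compounds shown alone.

Measured in a functional assay on MDA-MB-468 cells (Homo sapiens) for antiproliferative activity, read by MTT assay, with a stated time of 72 h; on this read-out higher numbers stand for weaker inhibition and lower numbers for stronger inhibition:
Compound 1 `CCCn1ccnc1-c1cc(OC)c(OC)c(OC)c1`: > 100000 nM, a limit
Compound 2 `CCCCn1ccnc1-c1cc(OC)c(OC)c(OC)c1`: 44100 nM
Compound 3 `COc1cc(-c2nccn2S(=O)(=O)c2ccccc2)cc(OC)c1OC`: > 100000 nM, a limit

Going by the values given here, compound 2 holds the only actual number in this assay. Beside it stands (the limit of > 100000 nM in this assay, at which 2 of the 3 values shown sit).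

The next compound is compound 4 `COc1cc(-c2nccn2-c2ccc(C)cc2)cc(OC)c1OC`, which carries 4-methylphenyl in place of butyl on an aromatic nitrogen.

Two results bear on this change. Among the compounds with values here, the one measured step on that nitrogen is an at least 2.2-fold lower number from compound 1 to compound 2 (0.35 log units; beyond the scatter), with the longer chain giving the lower number. Compound 3 carries a different group on that nitrogen and gives > 100000 nM, which is a limit. Compound 3 therefore goes against any simple trend towards lower numbers with larger groups there.

With only this to go on, a moderate move to a lower number is expected, with wide uncertainty. The expected step is a 5.5-fold lower number from compound 2 to compound 4 (0.74 log units; beyond the scatter).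

For compound 4 the estimated value is 8000 nM, with an expected range from 400 nM to 70000 nM.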

Compound 4, half-maximal inhibitory concentration: 400 nM
The estimate for compound 4 lay 20-fold (1.30 log units) above the measured number; the measured number falls inside the stated range.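

In this assay, replacing butyl with 4-methylphenyl on the aromatic nitrogen gives a 110-fold lower number from compound 2 to compound 4 (2.04 log units; beyond the scatter), so this position accepts a six-membered aromatic ring and not only a saturated chain. Set against propyl, the same group gives an at least 250-fold lower number from compound 1 to compound 4 (2.39 log units; beyond the scatter), and that step rests on a limit of the assay for compound 1. An aromatic ring on this nitrogen does not by itself ensure a low number, since compound 3, whose ring is attached through a sulfonyl group, also stands at a limit of the assay: the limit of > 100000 nM in this assay, at which 2 of the 4 values shown sit.

The compounds shown leave open how much the methyl of the 4-methylphenyl group contributes compared with a plain phenyl. They also leave open how a chlorophenyl, a methoxyphenyl or a benzyl group on this nitrogen would read.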